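Alkoxy chain length on the benzylamide aromatic ring

The compounds below may be only part of what the source reports. "The series", "measured", "known", "first", "only" and "open" are said of these compounds alone.

compound 1 `CCCCN(C)c1cc(C(C)(C)C)ccc1CNC(=O)C(C)c1ccc(NS(C)(=O)=O)c(F)c1`: 1 nM
compound 2 `CCCOc1cc(C(C)(C)C)ccc1CNC(=O)C(C)c1ccc(NS(C)(=O)=O)c(F)c1`: 4.4 nM

Among the compounds with values here, in an assay on cells for antagonist activity at transient receptor potential cation channel subfamily V member 1 (Homo sapiens), read by FLIPR and calcium flux, with a stated time of 6 min (on this read-out lower numbers stand for stronger inhibition and higher numbers for weaker inhibition), compound 2 gives the higher of the two numbers; its only neighbour is compound 1, separated by the step of a 4.4-fold higher number from compound 1 to compound 2 (0.64 log units; beyond the scatter). Compound 3 `CCCCCCOc1cc(C(C)(C)C)ccc1CNC(=O)C(C)c1ccc(NS(C)(=O)=O)c(F)c1` is compound 2 with propyl in place of hydrogen on a saturated chain carbon, three bonds along the chain from an oxygen on an aromatic ring. Within the data shown here, no measured step bears directly on this: the one step in hand exchanges butyl(methyl)amino for propoxy and says nothing about lengthening an alkoxy chain. Expected for compound 3 is therefore little movement, a 1.8-fold higher number from compound 2 to compound 3 (0.26 log units; within the scatter), with wide uncertainty in either direction. The estimate for compound 3 is 8 nM (range 2 nM to 40 nM).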

Compound 3, inhibition constant: 0.5 nM
The estimate for compound 3 lay 16-fold (1.20 log units) above the measured number; the whole stated range lies above it.
By their numbers in this assay, from the lowest: compounds 3 and 1 (each within the scatter of the next); then compound 2.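

Extending the alkoxy chain from propyl to hexyl at this position does not cost activity: the step is an 8.8-fold lower number from compound 2 to compound 3 (0.94 log units; beyond the scatter), so the propoxy of compound 2 marks no upper limit on chain length here. The hexyloxy chain also closes the gap to the butyl(methyl)amino group, with a 2.0-fold lower number from compound 1 to compound 3 (0.30 log units; within the scatter) leaving the two within the scatter. No measured evidence explains the effect of the longer chain. On these data alone, the butoxy and pentyloxy chains remain open, so the shape of the trend between propoxy and hexyloxy is unknown. As far as these compounds go, whether an octyloxy chain or a terminal amine would be accepted also remains open.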